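Swapping a Hydroxy for a Trifluoromethyl on the Aniline Ring

The source may report more compounds than this note shows. Statements on the series, on what has been measured and on what is new or still open speak of the compounds shown alone.

Of the compounds shown here, three sharing one core have been tested in a functional assay on RCC4 cells (Homo sapiens) for inhibition, read by XTT assay, with a stated time of 4 days; a lower number here means a stronger inhibitor, a higher number a weaker inhibitor. Compound 1 `Cc1cccc(Nc2nc(-c3ccncc3)c(C)s2)c1` gives 10000 nM, compound 3 `Fc1ccccc1Nc1nc(-c2ccncc2)cs1` gives 14500 nM, and compound 2 `Oc1ccc(Nc2nc(-c3ccncc3)cs2)cc1` gives 5370 nM. Compound 2 has the lowest of the three numbers, but its gap to compound 1 falls within the scatter of this assay, so only compound 3 can be called clearly weaker than it.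

Compound 4 `FC(F)(F)c1ccc(Nc2nc(-c3ccncc3)cs2)cc1` is not yet measured. It differs from compound 2 in one place: trifluoromethyl in place of hydroxy on an aromatic carbon. Among the compounds with values here, no measured pair here shows what this exchange does, so the expectation rests on how narrow the spread of the three known values is. Compound 4 is expected to land near the others in this assay, with an estimated value of 8000 nM and a range from 2500 nM to 25000 nM. The step expected for compound 4 in this assay is a 1.5-fold higher number from compound 2 to compound 4 (0.17 log units; within the scatter), a modest move toward a higher number that may not exceed the scatter.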

Compound 4, half-maximal inhibitory concentration: 40700 nM
For compound 4 the middle estimate is 5.1-fold (0.71 log units) below the measured one; measured number above the stated range.
By their numbers in this assay, from the lowest: compounds 2, 1 and 3 (each within the scatter of the next, the first and the last beyond it); then compound 4.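

In this assay, within the data shown here, trifluoromethyl in place of hydroxy gives a 7.6-fold higher number from compound 2 to compound 4 (0.88 log units; beyond the scatter), the first single-place comparison in this set. Among these compounds, it shows that the group on this aromatic carbon, para to a large group, can shift the number beyond the scatter, which the earlier compounds, with no one-place pair among them, could not show. Since the exchange replaces hydroxy, with its hydrogen-bond donor and acceptor, with a larger group that has neither, this one pair cannot separate those differences, and no measurement here explains the step.

On these data alone, it remains open whether hydroxy lowers the number or trifluoromethyl raises it, a question that plain hydrogen at this place could help settle. Where an amine, a methoxy group or a carboxylic acid would fall relative to compound 2 and compound 4 is also unanswered.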